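One ring swapped, one number still awaited

The source may report more compounds than this note shows. Statements on the series, on what has been measured and on what is new or still open speak of the compounds shown alone.

Measured in a physicochemical assay for lipophilicity (on this read-out lower numbers stand for lower lipophilicity and higher numbers for higher lipophilicity), so far:
Compound 1 (`COc1ccc(CN(CCN(C)C)c2ccc(N)cc2)cc1`) gives 3.13
Compound 2 (`COc1ccc(CN(CCN(C)C)c2ccc(C)cc2)cc1`) gives 4.43

Of these two numbers, compound 2 stands highest (4.43) and compound 1 lies beneath it. Compound 3 (`COc1ccc(CN(CCN(C)C)c2ccc(N)cn2)cc1`) has not yet been measured. It carries 5-aminopyridin-2-yl in place of 4-methylphenyl on an amine nitrogen. Within the data shown here, the one measured step that bears on this, methyl in place of amino on an aromatic carbon, was large (a number 1.30 log units higher from compound 1 to compound 2 (beyond the scatter)) and beyond the scatter. Compound 3 carries an amino group, as does compound 1 (3.13), so a large step downward is expected in this assay. Among the measured compounds shown here, no measured step shows what the ring with 1 hetero atom adds on its own. The expected step is somewhat larger than the measured one (a number 1.83 log units lower from compound 2 to compound 3 (beyond the scatter)). Compound 3 is estimated at 2.6 (expected range 1.9 to 3.3).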

Compound 3, partition coefficient: 2.56
For compound 3 the middle estimate is 0.04 log units above the measured one, within the range that was stated.
By their numbers in this assay, from the lowest: compound 3; then compound 1; then compound 2.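

In this assay, the ring with 1 hetero atom now has a step of its own: with the amino group present on both sides, the move to 5-aminopyridin-2-yl gives a number 0.57 log units lower from compound 1 to compound 3 (beyond the scatter) and so moves the read-out beyond the scatter. The full change from 4-methylphenyl to 5-aminopyridin-2-yl at this place gives a number 1.87 log units lower from compound 2 to compound 3 (beyond the scatter) and leaves compound 3 lowest of the three, so both steps into compound 3 run downward. No measurement on hand accounts for either step.

The compounds shown leave open whether the ring with 1 hetero atom would give a similar step when it carries a methyl group instead of the amino group. They also do not show how a hydroxyl group or a carboxylic acid in that place on the ring would read.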